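Chloro to methyl on the outer aryl ring of the series

The source may report more compounds than this note shows. Statements on the series, on what has been measured and on what is new or still open speak of the compounds shown alone.

Measured so far:
compound 1 `N[C@@H](COP(=O)(O)O[C@@H]1CCCO[C@@H]1COC(=O)CCc1ccccc1OCc1cccc(Oc2ccc(Cl)cc2)c1)C(=O)O`: 16.6%
compound 2 `CCCCCCCC/C=C\CCCCCCCC(=O)O[C@H]1C=CCO[C@@H]1COP(=O)(O)OC[C@H](N)C(=O)O`: "not active" (no number reported)

Among the measured compounds shown here, in an assay on HEK293-A cells for agonist activity at probable G-protein coupled receptor 34 (Mus musculus), with a stated time of 1.5 h (on this read-out lower numbers stand for smaller maximal responses and higher numbers for larger maximal responses), compound 1 gives 16.6% and is the only compound of the series with a number. Compound 2 `CCCCCCCC/C=C\CCCCCCCC(=O)O[C@H]1C=CCO[C@@H]1COP(=O)(O)OC[C@H](N)C(=O)O` is reported in this assay as "not active" (no number reported) without a number. For the measured compounds named here, no step between two measured compounds is available, so the size of a single change in this read-out is unknown.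

Compound 3 `Cc1ccc(Oc2cccc(COc3ccccc3CCC(=O)OC[C@H]3OCCC[C@H]3OP(=O)(O)OC[C@H](N)C(=O)O)c2)cc1` is not yet measured. It differs from compound 1 by methyl in place of chloro on an aromatic carbon. The difference is one heavy atom at the same aromatic carbon, with no change in donors, acceptors or charge. Nothing in the series shows how this assay answers such an exchange, so the expected step from compound 1 to compound 3, a number 0.4 percentage points higher from compound 1 to compound 3 (within the scatter), is expected to lie within the scatter, in no particular direction. Compound 3 is therefore expected to give about 17%, with a range from 6% to 30%.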

Compound 3, largest response reached (Emax), in percent of the reference or control that the assay uses: 15.2%
Compound 3: the middle estimate sits 1.8 percentage points above what was measured; measured number inside the range.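

In this assay, the change from 4-chlorophenoxy to 4-methylphenoxy comes with a number 1.4 percentage points lower from compound 1 to compound 3 (within the scatter). Among the compounds shown here, this is the first step that can be read, and it shows that this aromatic carbon, para to a large group, takes methyl in place of chloro with no difference that can be told from the scatter on this read-out. Nothing measured here bears on why the two groups give matching responses.

From the compounds shown here alone, whether an amine, a carboxylic acid or a longer chain on the same aromatic carbon would move the maximal response beyond the scatter remains open. This single exchange also says nothing about how the read-out answers changes elsewhere on the shared core.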